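The compounds below may be only part of what the source reports. "The series", "measured", "known", "first", "only" and "open" are said of these compounds alone.

In a functional assay (aorta) for inhibition, with Rattus norvegicus as the target, with a stated time of 8 days (on this read-out higher numbers stand for weaker inhibition and lower numbers for stronger inhibition), compound 1 `Cc1nsc(-c2ccc(N3CCN(c4cccc(C#N)c4)CC3)nn2)n1` gives 3 nM. For compound 2 `Cc1nsc(-c2ccc(N3CCN(c4cccc(N)c4)CC3)nn2)n1`, the assay reports only a limit, > 100 nM. Among the compounds with values here, the one measured step that bears on what follows is an at least 33-fold higher number from compound 1 to compound 2 (1.52 log units; beyond the scatter), which is large and comes with amino in place of cyano on an aromatic carbon. Compound 3 `COc1cccc(N2CCN(c3ccc(-c4nc(C)ns4)nn3)CC2)c1` changes that same group, with methoxy in place of amino on an aromatic carbon, meta to a large group: methoxy in place of amino on an aromatic carbon. Amino is the group that arrived with the large rise in compound 2 at > 100 nM, so replacing it is expected to give a lower number in this assay. Methoxy is not cyano, however, so only a partial return towards compound 1 is expected. The expected change is an at least 3.3-fold lower number from compound 2 to compound 3 (0.52 log units; beyond the scatter). For compound 3 the estimated value is 30 nM, within an expected range of 6 nM to 150 nM.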

Compound 3, half-maximal inhibitory concentration: 7 nM
For compound 3 the middle estimate is 4.3-fold (0.63 log units) above the measured one; the measured number falls inside the stated range.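

The value of compound 2 in this assay is a limit and not a number: the limit of > 100 nM in this assay, at which 1 of the 3 values shown sits. Even so, methoxy gives an at least 14-fold lower number from compound 2 to compound 3 (1.15 log units; beyond the scatter), so this aromatic carbon can carry a group other than cyano and still keep the number low, and the poor result belongs to amino rather than to the position as a whole. Set against cyano, methoxy shows a 2.3-fold higher number from compound 1 to compound 3 (0.37 log units; beyond the scatter), a modest step, so the two groups lie close together here while amino stands well apart.

Three groups at one place cannot show which feature of a group sets the number, and the limit hides the true size of the loss with amino. As far as these compounds go, how a hydroxyl, a chlorine or a dimethylamino group would read on this carbon remains open.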